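Carbamate series: fluorine added to the cyanophenyl ring

A few compounds are considered here, and "the series" means these few. Any claim that something is new, unique, unknown or untested is made for them only; others in the source may bear on it.

Measured so far in an assay on isolated protein for inhibition of Monoglyceride lipase (Rattus norvegicus), read by fluorescence, with stated times of 15 min and 3 h; on this read-out lower numbers stand for stronger inhibition and higher numbers for weaker inhibition:
compound 1, `N#Cc1cccc(OC(=O)N2CCC(C(c3ccccc3)c3ccccc3)CC2)c1`: 36.5 nM
compound 2, `N#Cc1cccc(OC(=O)N2CCC(C(c3ccc(Cl)cc3)c3ccc(Cl)cc3)CC2)c1`: 32.5 nM
compound 3, `N#Cc1cccc(OC(=O)N2CCC(Cc3ccccc3)CC2)c1`: 157 nM

Compound 1 holds the second highest of the three numbers. Compound 2 sits closest to it, the two values lying within the usual scatter of each other, so no order between compound 1 and compound 2 is claimed. Compound 3 is furthest away, reached by a 4.3-fold higher number from compound 1 to compound 3 (0.63 log units; beyond the scatter), which is a modest but real weakening.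

The step now considered leads from compound 1 to compound 4, `N#Cc1cc(F)cc(OC(=O)N2CCC(C(c3ccccc3)c3ccccc3)CC2)c1`, and consists of fluoro in place of hydrogen on an aromatic carbon. For the measured compounds named here, the change sits on the aryl carbamate side of the shared core, while the one measured step, from compound 1 to compound 3, concerns the other end of the molecule; it therefore says little about the present change, and no measured pair shows a fluoro-for-hydrogen exchange on this ring. With nothing in this assay to point either way, compound 4 is expected to fall close to compound 1, with a step of a 1.2-fold lower number from compound 1 to compound 4 (0.09 log units; within the scatter) that stays within the scatter. The estimate for compound 4 in this assay is therefore 30 nM, with a range from 12 nM to 90 nM.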

Compound 4, half-maximal inhibitory concentration: 105 nM
Beside the measured number, compound 4's estimate is 3.5-fold (0.54 log units) below it, and the stated range ends below it.
By their numbers in this assay, from the lowest: compounds 2 and 1 (each within the scatter of the next); then compounds 4 and 3 (each within the scatter of the next).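

In this assay, the aryl carbamate side of the shared core proves responsive to a very small edit: going from 3-cyanophenyl to 3-cyano-5-fluorophenyl gives a 2.9-fold higher number from compound 1 to compound 4 (0.46 log units; beyond the scatter). For the compounds shown here, until now the only readable step, a 4.3-fold higher number from compound 1 to compound 3 (0.63 log units; beyond the scatter), lay at the other end of the molecule, so this is the first sign that the aromatic carbon meta to a cyano group and meta to a large group is not a free place for substitution, since one fluorine, with no hydrogen-bond donor or acceptor and no net charge, already weakens inhibition beyond the scatter. Nothing at hand explains the direction or size of this step.

The compounds shown leave open whether the weakening belongs to fluoro itself or to any substituent at this place, which chloro, methyl or methoxy on the same aromatic carbon would help to separate. Also open, going by these compounds, is whether the same fluoro exchange gives a step of similar size on the core of compound 2 or compound 3, as one pair cannot establish a trend across the series.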